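From phenyl to 3-methylphenyl in compound 3

The source may hold more compounds than are shown below. What is called first, only, known or untested is meant among the compounds shown, and "the series" means these compounds.

In an ADME assay on BHK-21 cells (Mesocricetus auratus) for cytotoxicity, read by MTT assay, with a stated time of 72 h (on this read-out lower numbers stand for higher toxicity in this test and higher numbers for lower toxicity in this test), compound 1 (`NS(=O)(=O)c1ccc(N2N=C(c3ccc(OCc4ccccc4)cc3)CC2c2ccccc2)cc1`) gives 80000 nM while compound 2 (`NS(=O)(=O)c1ccc(N2N=C(c3ccc(Oc4ccccc4)cc3)CC2c2ccccc2)cc1`) gives 11000 nM and so holds the lower of the two numbers. For the measured compounds named here, the only measured step is a 7.3-fold lower number from compound 1 to compound 2 (0.86 log units; beyond the scatter) and it is modest though beyond the scatter, with phenyl in place of benzyl on an oxygen on an aromatic ring.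

Compound 3 (`Cc1cccc(C2CC(c3ccc(Oc4ccccc4)cc3)=NN2c2ccc(S(N)(=O)=O)cc2)c1`) differs from compound 2 by methyl in place of hydrogen on an aromatic carbon, the change from phenyl to 3-methylphenyl. Going by the values given here, this change lies elsewhere in the structure than the measured step, which therefore shows only that the numbers in this assay can move. Among the compounds with values here, it gives no direction for the new change, and no measured pair tests a substituent at this place. A step beyond the scatter is not expected. The estimated step is a 1.1-fold lower number from compound 2 to compound 3 (0.04 log units; within the scatter) and stays small. For compound 3 the expected value is 10000 nM with an estimated range from 4500 nM to 25000 nM in this test.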

Compound 3, half-maximal cytotoxic concentration: 8000 nM
Compound 3: the middle estimate sits 1.3-fold (0.10 log units) above what was measured; the measured number falls inside the stated range.
By their numbers in this assay, from the lowest: compounds 3 and 2 (each within the scatter of the next); then compound 1.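

In this assay the change to 3-methylphenyl gives a 1.4-fold lower number from compound 2 to compound 3 (0.14 log units; within the scatter) and so leaves compound 3 and compound 2 indistinguishable on this read-out. For the compounds shown here, this is the only measured pair at this place, and it shows that methyl on an aromatic carbon of this six-membered aromatic ring, meta to a large group, is accommodated with no change in the number that can be told from the scatter, unlike the change on the oxygen, a 7.3-fold lower number from compound 1 to compound 2 (0.86 log units; beyond the scatter) which lies beyond the scatter at a different place in the structure. No available evidence bears on the reason for this result.

As far as these compounds go, one methyl at one place sets no trend for this ring, so it remains open whether a longer chain, an amine or a carboxylic acid at the same place would shift the number beyond the scatter or leave it as flat as methyl does. Also open, from the compounds shown here alone, is whether the same methyl would behave alike with the benzyl on the oxygen found in compound 1, where the number is higher.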